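Moving an Alkyl Group Around the Aryl Ring

The source may hold more compounds than are shown below. What is called first, only, known or untested is meant among the compounds shown, and "the series" means these compounds.

Three measured compounds share one core and differ only in the aryl group carried on the ring nitrogen. In a functional assay on HepG2 cells (Homo sapiens) for inhibition, read by MTT assay, with a stated time of 72 h (on this read-out higher numbers stand for weaker inhibition and lower numbers for stronger inhibition), compound 1 `Cc1ccc(-n2cc(COc3cccc(NC(=O)Nc4ccc(Cl)c(C(F)(F)F)c4)c3)nn2)cc1` gives 5430 nM, the highest of the three numbers and thus the weakest inhibitor here, since both of its steps to the others lie beyond the scatter. In this assay compound 2 `CCc1ccc(-n2cc(COc3cccc(NC(=O)Nc4ccc(Cl)c(C(F)(F)F)c4)c3)nn2)cc1` gives 1950 nM, and in this assay compound 3 `CC(C)c1ccccc1-n1cc(COc2cccc(NC(=O)Nc3ccc(Cl)c(C(F)(F)F)c3)c2)nn1` gives 1900 nM. The steps are a 2.8-fold lower number from compound 1 to compound 2 (0.44 log units; beyond the scatter) and a 2.9-fold lower number from compound 1 to compound 3 (0.46 log units; beyond the scatter), while a 1.0-fold lower number from compound 2 to compound 3 (0.01 log units; within the scatter).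

Compound 4 `CC(C)c1cccc(-n2cc(COc3cccc(NC(=O)Nc4ccc(Cl)c(C(F)(F)F)c4)c3)nn2)c1` differs from compound 1 by 3-isopropylphenyl in place of 4-methylphenyl on an aromatic nitrogen. Both measured steps that enlarge the alkyl portion of this aryl group bear on it, and each gave a modest lowering of similar size, whether the change was 1>2 or 1>3. A modest lowering in this assay is therefore expected for compound 4, with no basis for anything larger. Compound 4 is estimated at 2000 nM, ranging from 900 nM to 4500 nM. This estimate means an expected step of a 2.7-fold lower number from compound 1 to compound 4 (0.43 log units; beyond the scatter).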

Compound 4, half-maximal inhibitory concentration: 3250 nM
For compound 4 the middle estimate is 1.6-fold (0.21 log units) below the measured one, and the stated range covers the measured number.
By their numbers in this assay, from the lowest: compounds 3, 2, 4 and 1 (each within the scatter of the next, the first and the last beyond it).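

In this assay, 3-isopropylphenyl in place of 4-methylphenyl gives a 1.7-fold lower number from compound 1 to compound 4 (0.22 log units; within the scatter), so enlarging the alkyl portion of the aryl group does not always carry the number beyond the scatter, as the two earlier steps from compound 1 did. The isopropyl group's place on the aryl ring also makes no readable difference, with a 1.7-fold higher number from compound 3 to compound 4 (0.23 log units; within the scatter), and the change from 4-ethylphenyl gives a 1.7-fold higher number from compound 2 to compound 4 (0.22 log units; within the scatter), which leaves compound 4 inseparable from each of the other three. No measurement available here explains these results.

The compounds shown leave open how 4-isopropylphenyl would compare, which would test the isopropyl group at the third place on the ring. They also do not tell whether an amine or a carboxylic acid on the aryl ring would shift the number further than these alkyl groups.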